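Swapping 4-chlorophenyl for 2-hydroxyphenyl on a shared core

The source may hold more compounds than are shown below. What is called first, only, known or untested is meant among the compounds shown, and "the series" means these compounds.

Of the compounds shown here, three have been measured in an ADME assay on HepG2 cells (Homo sapiens), read by MTT assay, with a stated time of 72 h (a lower number here means a stronger inhibitor, a higher number a weaker inhibitor), so far. Compound 1 (`CC12CCC(C/C1=N\NC(=O)c1ccc(C(F)(F)F)cc1)C2(C)C`) gives > 100000 nM as a limit of the assay and not a number. Among the compounds with values here, compound 2 (`O=C(N/N=C/c1cc(Cl)ccc1O)c1ccc(C(F)(F)F)cc1`) gives 13600 nM as the only true number among the three. Compound 3 (`O=C(N/N=C/c1ccc(Cl)cc1)c1ccc(C(F)(F)F)cc1`) gives > 100000 nM as a limit too and not a number, so its standing is known only as that limit, which it shares with compound 1.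

Compound 4 (`O=C(N/N=C/c1ccccc1O)c1ccc(C(F)(F)F)cc1`) has not yet been measured. It carries 2-hydroxyphenyl in place of 4-chlorophenyl on a carbon with a double bond to nitrogen and is otherwise the same as compound 3. Within the data shown here, no measured step between two compounds is available to guide this change. The expectation leans on compound 2, which gives 13600 nM with a hydroxyl group on the corresponding ring. Compound 1 and compound 3 have no such group and stay at the limit. A shift toward stronger inhibition is therefore expected, and the estimated step is an at least 3.3-fold lower number from compound 3 to compound 4 (0.52 log units; beyond the scatter) in this assay terms. A result at the limit remains possible. For compound 4 the estimated value is 30000 nM with an expected range from 9000 nM to 100000 nM for this compound.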

Compound 4, half-maximal inhibitory concentration: 6200 nM
Compound 4: middle estimate off by 4.8-fold (0.68 log units), on the high side, and the stated range ends above it.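

In this assay, within the data shown here, 2-hydroxyphenyl in place of 4-chlorophenyl on a carbon with a double bond to nitrogen gives an at least 16-fold lower number from compound 3 to compound 4 (1.20 log units; beyond the scatter), the first direct reading of this change on the shared core. Compound 3 stands at a limit of the assay and not at a number, so this step gives only a bound on the size of the change: the limit of > 100000 nM in this assay, at which 2 of the 4 values shown sit.

Hydrogen in place of chloro on an aromatic carbon then gives a 2.2-fold lower number from compound 2 to compound 4 (0.34 log units; beyond the scatter), a modest step that shows the 2-hydroxyphenyl ring needs no chloro to give a measurable value, and that the value is lower without it.

The change from 4-chlorophenyl to 2-hydroxyphenyl removes the chloro and adds the hydroxyl at once, and no compound shown carries a plain phenyl ring, so the two parts of that step cannot be separated. As far as these compounds go, it also remains open whether a methoxy group or an amine in place of the hydroxyl would keep a measurable value, and whether any of this holds with a group such as a nitrile in place of the trifluoromethyl.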